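Inverting a Ring Stereocentre in a Fatty Acid Receptor Agonist

A few compounds are considered here, and "the series" means these few. Any claim that something is new, unique, unknown or untested is made for them only; others in the source may bear on it.

Of the compounds shown here, two have so far been measured in a functional assay on cells for agonist activity at Free fatty acid receptor 1 (Homo sapiens), read by FLIPR and calcium flux; a lower number here means that less compound is needed, a higher number that more compound is needed for the effect. Compound 1 `COc1ccc(F)c(N2CCC(Cc3ccc(N4C[C@H](C(F)(F)F)C[C@@H]4CC(=O)O)cc3)CC2)c1` gives 530 nM. Compound 2 `COc1ccc(F)c(N2CC[C@H](COc3ccc(N4C[C@H](C(F)(F)F)C[C@@H]4CC(=O)O)cc3)C2)c1` gives 940 nM in this assay; this number and that of compound 1 lie within the usual scatter of each other, so the two cannot be told apart on the present data. Compound 3 `COc1ccc(F)c(N2CC[C@@H](COc3ccc(N4C[C@H](C(F)(F)F)C[C@@H]4CC(=O)O)cc3)C2)c1` has not yet been measured. It differs from compound 2 as follows: the two compounds have the same atoms and bonds and differ only in configuration as drawn: 1 of 3 stereo elements differ; a stereocentre at a saturated ring carbon is drawn S in compound 2 and R in compound 3. Among the compounds with values here, no measured pair shows what inverting this saturated ring carbon does here, so the direction of the step is open; either configuration might prove the more active one, and the data give no basis for favouring one. The step from compound 2 to compound 3 is therefore expected to be a 1.3-fold higher number from compound 2 to compound 3 (0.11 log units; within the scatter), none beyond the scatter, but with a wide band around it. Compound 3 is expected to give 1200 nM in this assay, within a range of 250 nM to 6000 nM.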

Compound 3, half-maximal effective concentration: 630 nM
Beside the measured number, compound 3's estimate is 1.9-fold (0.28 log units) above it; measured number inside the range.
By their numbers in this assay, from the lowest: compounds 1, 3 and 2 (each within the scatter of the next).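

In this assay, inverting the saturated ring carbon from S to R gives a 1.5-fold lower number from compound 2 to compound 3 (0.17 log units; within the scatter). Within the data shown here, this pair is the first to isolate a single stereocentre, and it can be read that way because nothing else separates the two compounds: the fact that compounds 2 and 3 differ only in the configuration as drawn. At this position, with the rest of compound 2 held constant, neither configuration can be told apart from the other, so the direction left open earlier remains unresolved and no effect of the inversion can be read beyond the scatter.

The compounds shown leave open whether the same inversion would stay within the scatter if a nitrile replaced the methoxy group or an amine replaced the carboxylic acid. They also leave open what inverting either of the two other stereo elements would do in this assay.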